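Removing the N-aryl group from a fused lactam core

The source may report more compounds than this note shows. Statements on the series, on what has been measured and on what is new or still open speak of the compounds shown alone.

All values come from a functional assay on A549 cells (Homo sapiens) for antiproliferative activity, read by MTT assay, with a stated time of 72 h; on this read-out higher numbers stand for weaker inhibition and lower numbers for stronger inhibition.

Compound 1, `COc1cccc(N2C(=O)COc3ccc(-c4cnc(Cl)c(NS(=O)(=O)c5ccc(F)cc5)c4)cc32)c1`, gives 32700 nM.
Compound 2, `O=C1COc2ccc(-c3cnc(Cl)c(NS(=O)(=O)c4ccc(F)cc4)c3)cc2N1`, reaches only the limit of the assay, > 40000 nM.
Compound 3, `COc1cccc(N2C(=O)COc3ccc(-c4ccc(O)cc4)cc32)c1`, likewise reaches only the limit of the assay, > 40000 nM.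

Compounds 1 and 2 share one core and differ in a single place: hydrogen in place of 3-methoxyphenyl on an amide-type nitrogen in a ring. That change gave an at least 1.2-fold higher number from compound 1 to compound 2 (0.08 log units; that floor lies within the scatter), so the number moved toward the limit rather than away from it. The same change is now made on a second core, from compound 3 to compound 4, `O=C1COc2ccc(-c3ccc(O)cc3)cc2N1`: hydrogen in place of 3-methoxyphenyl on an amide-type nitrogen in a ring. The difference between the core of compound 1 and the core of compound 3 is not broken down here.

Two of the three measured values sit at the limit of > 40000 nM in this assay, at which 2 of the 3 values shown sit, which leaves little room to see any step downward or upward in this direction. Compound 3 already sits at that limit. The expected step is a step that the limit leaves unreadable from compound 3 to compound 4, an estimate that rests on the measured step of an at least 1.2-fold higher number from compound 1 to compound 2 (0.08 log units; that floor lies within the scatter), where taking the same group away did not lower the number. Compound 4 is therefore expected to give 60000 nM, with an estimated range from 30000 nM to 200000 nM, and it is likely that the assay will again report only a limit for compound 4 rather than a number.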

Compound 4, half-maximal inhibitory concentration: > 40000 nM
Compound 4: only a limit was reported; the forecaster's own chance of this, stated with the estimate: 85%; the middle value does not contradict the limit.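

Compound 4 gives > 40000 nM, which is a limit of the assay and not a number. Compound 3 also gives only a limit, so no step can be read between compound 3 and compound 4: the limit of > 40000 nM in this assay, at which 3 of the 4 values shown sit.

The compounds shown leave open whether replacing 3-methoxyphenyl with hydrogen on the core of compound 3 changes the antiproliferative activity at all, and by how much.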